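Working notes on a dihydropyridine ester pair and one chloro analogue

This account rests on a few compounds, and the source may have more. Where it says the series, first, only, none or still open, it means among the compounds named here.

Measured so far:
- compound 1 `CCOC(=O)C1=C(C)N(c2ccc(Cl)cc2)C=CC1c1ccccc1`: -31.1%
- compound 2 `CC1=C(C(=O)OC(C)(C)C)C(c2ccccc2)C=CN1c1ccccc1`: -37.1%

In a functional assay, tested at 200 ug/mL (on this read-out lower numbers stand for a stronger effect and higher numbers for a weaker effect at the one concentration tested), compound 2 gives -37.1%. For the measured compounds named here, its only measured neighbour, compound 1, differs from it at both the ester and the aryl group on nitrogen, and in this assay compound 1 gives -31.1%, a number within the usual scatter of the value for compound 2. Going by the values given here, no pair of measured compounds differs in one place, so no single structural change has a measured step attached to it.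

Compound 3 `CC1=C(C(=O)OC(C)(C)C)C(c2ccccc2)C=CN1c1ccc(Cl)cc1` is the next compound to be measured in this assay. It differs from compound 2 by chloro in place of hydrogen on an aromatic carbon. The two measured values together give no sign that this change moves the read-out beyond the scatter; an estimated step of a number 3.1 percentage points higher from compound 2 to compound 3 (within the scatter) is expected to stay inside it. Compound 3 is therefore estimated at -34%, with a range from -52% to -16%.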

Compound 3, a percentage reported as activity, at one concentration (the size of the read-out at that concentration, not a potency): -34.6%
Estimate against measurement, compound 3: 0.6 percentage points above, within the range that was stated.
By their numbers in this assay, from the lowest: compounds 2, 3 and 1 (each within the scatter of the next).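

Chloro in place of hydrogen on an aromatic carbon, para to a large group, gives a number 2.5 percentage points higher from compound 2 to compound 3 (within the scatter) in this assay and so isolates this change for the first time, with no shift beyond the scatter at this position. Tert-butyl in place of ethyl on an oxygen next to a carbonyl group gives a number 3.5 percentage points lower from compound 1 to compound 3 (within the scatter) and this second single change also stays inside the scatter, so the closeness of compound 1 and compound 2 now resolves into two small steps. No available data speak to the reason for either step.

On these data alone, whether an amine or a carboxylic acid in place of chloro at this position would move the read-out in this assay remains open. As far as these compounds go, a longer chain in place of tert-butyl on the ester oxygen is equally open.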